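Adding a Second Fluorine to the Sulfonyl Aryl Ring

The compounds below may be only part of what the source reports. "The series", "measured", "known", "first", "only" and "open" are said of these compounds alone.

Compound 2 `COc1ccc(-c2c(S(=O)(=O)c3ccc(F)cc3)cnc3cc(F)ccc23)cc1` has been tested in an ADME assay on microsomes from liver (Homo sapiens) for metabolic stability, tested at 2.5 uM (a higher number here means faster removal of the compound, a lower number slower removal), where compound 2 gives 1.77 mL/min. Among the measured compounds shown here, of the two numbers so far this is the lower, but compound 1 `COc1ccc(-c2c(S(=O)(=O)c3cccc(F)c3)cnc3cc(F)ccc23)cc1`, which gives 1.89 mL/min, lies within the scatter of it. For the measured compounds named here, the only measured step is a 1.1-fold lower number from compound 1 to compound 2 (0.03 log units; within the scatter). Compound 3 `COc1ccc(-c2c(S(=O)(=O)c3ccc(F)c(F)c3)cnc3cc(F)ccc23)cc1` differs from compound 2 by fluoro in place of hydrogen on an aromatic carbon. Going by the values given here, no measured step adds a second fluoro group, and the one step on this ring stayed within the scatter, so no shift beyond the scatter is expected in this assay: a 1.0-fold higher number from compound 2 to compound 3 (0.01 log units; within the scatter). Compound 3 is therefore estimated at 1.8 mL/min, within 1 mL/min to 3.2 mL/min.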

Compound 3, intrinsic clearance in a liver preparation (reported as CLH), per the amount of preparation that the assay uses: 1.1 mL/min
Estimate against measurement, compound 3: 1.6-fold (0.21 log units) above; the measured number falls inside the stated range.
By their numbers in this assay, from the lowest: compounds 3, 2 and 1 (each within the scatter of the next).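

In this assay, the step of a 1.6-fold lower number from compound 2 to compound 3 (0.21 log units; within the scatter) and the step of a 1.7-fold lower number from compound 1 to compound 3 (0.24 log units; within the scatter) both stay within the scatter. Adding a second fluoro group to the ring on the sulfonyl sulfur, giving 3,4-difluorophenyl, therefore brings no clear shift from either compound with a single fluoro group, something the earlier pair of single-fluoro compounds could not show. No measured information is available to explain these steps. Still open, on these data alone, is whether a different group at this place, such as a nitrile or an amine, would move the number beyond the scatter.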